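The source may report more compounds than this note shows. Statements on the series, on what has been measured and on what is new or still open speak of the compounds shown alone.

In a physicochemical assay for lipophilicity, read by HPLC, at pH 7.5 (a lower number here means a more polar compound, a higher number a more lipophilic compound), compound 1 `CCOc1ccccc1-c1ccc(-c2nc3cnccc3cc2C#N)cc1` gives 3.8 and compound 2 `CC[C@@H](Nc1c(C#N)c(-c2ccc(-c3cccnc3C)cc2)nc2cnccc12)C(N)=O` gives 1.9, the lower of the two numbers and well beyond the usual scatter from the other. Compound 3 `CCOc1ccccc1-c1ccc(-c2nc3cnccc3c(N[C@H](CC)C(N)=O)c2C#N)cc1` departs from compound 2 in one group: 2-ethoxyphenyl in place of 2-methylpyridin-3-yl on an aromatic carbon, on an aromatic carbon, para to a large group. Going by the values given here, no measured pair shows this change alone. The entering 2-ethoxyphenyl is also carried by compound 1, at 3.8, so a clear rise that stops short of that value is expected. The expected size of the change is a number 1.20 log units higher from compound 2 to compound 3 (beyond the scatter). Compound 3 is estimated at 3.1, with a range from 2.6 to 3.6.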

Compound 3, distribution coefficient: 3
Compound 3: the middle estimate sits 0.10 log units above what was measured; the measured number falls inside the stated range.
By their numbers in this assay, from the lowest: compound 2; then compound 3; then compound 1.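

In this assay, going by these compounds alone, putting 2-ethoxyphenyl in place of 2-methylpyridin-3-yl gives a number 1.10 log units higher from compound 2 to compound 3 (beyond the scatter) as the first reading of this change alone. With 2-ethoxyphenyl kept, (1-carbamoylpropyl)amino in place of hydrogen on an aromatic carbon gives a number 0.80 log units lower from compound 1 to compound 3 (beyond the scatter) in the opposite direction. The gap between compound 1 and compound 2 therefore splits into two separate steps, with the aromatic group swap the larger.

Nothing measured here explains either step. From the compounds shown here alone, how a plain phenyl at the first place, or a carboxylic acid in place of the amide, would read remains open.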